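A few compounds are considered here, and "the series" means these few. Any claim that something is new, unique, unknown or untested is made for them only; others in the source may bear on it.

Measured so far:

Compound 1 `CCOC(=O)CCCCCOc1cccc(CN(C(=O)c2ccc(-c3cccc(N(C)C)c3)cc2)C(C)C)c1`: in an ADME assay on HepG2 cells (Homo sapiens) for cytotoxicity, read by CellTiter-Glo and resazurin assay, with a stated time of 72 h (a lower number here means that less compound is needed, a higher number that more compound is needed for the effect), compound 1 gives > 26000 nM, which is a limit of the assay rather than a number.
Compound 2 `CCOC(=O)CCCCCOc1cccc(CN(C(=O)c2ccc(-c3cccnc3)cc2)C(C)C)c1`: in this assay compound 2 gives > 26000 nM, again a limit rather than a number.

Compound 2 thus stands only at a limit, and nothing more exact is known about it in this assay. Among the compounds with values here, the one measured step, a step that the two limits leave unreadable from compound 1 to compound 2, cannot be read in size or direction because both of its values sit at the limit of > 26000 nM in this assay, at which 2 of the 2 values shown sit.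

The next compound, compound 3 `CCOC(=O)CCCCCOc1cccc(CN(C(=O)c2ccc(-c3cccc(C(C)=O)c3)cc2)C(C)C)c1`, differs from compound 2 in one place: 3-acetylphenyl in place of pyridin-3-yl on an aromatic carbon. Within the data shown here, no measured step bears on this change in a readable way, since the only step known, from compound 1 to compound 2, gives no size at all. With both measured compounds sitting at the limit, the expectation is that compound 3 will most likely also come back at the limit, with no step beyond the scatter. Compound 3 is therefore estimated at 30000 nM, in a range from 10000 nM to 100000 nM. The step this estimate implies, a step that the limit leaves unreadable from compound 2 to compound 3, is expected to be too small to read.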

Compound 3, half-maximal effective concentration: > 26000 nM
Compound 3: only a limit was reported; the forecaster's own chance of this, stated with the estimate: 75%; the middle value does not contradict the limit.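

In this assay compound 3 gives > 26000 nM, which is a limit and not a number. No step from compound 1 or compound 2 to compound 3 can be read, because all the values share one limit: the limit of > 26000 nM in this assay, at which 3 of the 3 values shown sit.

The compounds shown leave open whether the group changed between them affects the concentration needed for the effect, and by how much.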